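The compounds below may be only part of what the source reports. "The series", "measured", "known", "first", "only" and "open" are said of these compounds alone.

In a functional assay on CWR22R cells (Homo sapiens) for antiproliferative activity, read by propidium iodide staining, with a stated time of 96 h (a lower number here means a stronger inhibitor, a higher number a weaker inhibitor), compound 1, with structure `CC(O)(CSc1ccc(S(F)(F)(F)(F)F)cc1)C(=O)Nc1ccc(C#N)c(C(F)(F)F)c1`, gives 18100 nM, and compound 2, with structure `CC(O)(CSc1ccc(S(F)(F)(F)(F)F)cc1)C(=O)Nc1ccc([N+](=O)[O-])c(C(F)(F)F)c1`, gives 9200 nM. Between them there is one change, nitro in place of cyano on an aromatic carbon and it made a 2.0-fold lower number from compound 1 to compound 2 (0.29 log units; within the scatter). Compound 3, with structure `CC(O)(COc1ccc(S(F)(F)(F)(F)F)cc1)C(=O)Nc1ccc(C#N)c(C(F)(F)F)c1`, gives 28200 nM in this assay; how the core of compound 3 differs from the core of compound 1 is not broken down here. Compound 4, with structure `CC(O)(COc1ccc(S(F)(F)(F)(F)F)cc1)C(=O)Nc1ccc([N+](=O)[O-])c(C(F)(F)F)c1`, is not yet measured. It is made from compound 3 by the same change, nitro in place of cyano on an aromatic carbon at the same place as before. Because the earlier step was a 2.0-fold lower number from compound 1 to compound 2 (0.29 log units; within the scatter), the expected step here is a 2.0-fold lower number from compound 3 to compound 4 (0.30 log units; within the scatter). Compound 4 is therefore estimated at 14000 nM in this assay, likely between 7000 nM and 28000 nM.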

Compound 4, half-maximal inhibitory concentration: 14100 nM
Estimate against measurement, compound 4: 1.0-fold (0.00 log units) below, within the range that was stated.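

In this assay, putting nitro in place of cyano on the core of compound 3 gives a 2.0-fold lower number from compound 3 to compound 4 (0.30 log units; within the scatter). Set beside the earlier step, the change carries over from one core to the other with much the same size: the same change on two cores in this assay, a 2.0-fold lower number (0.29 log units; within the scatter) from compound 1 to compound 2 and a 2.0-fold lower number (0.30 log units; within the scatter) from compound 3 to compound 4, 1.0-fold (0.01 log units) apart, within the scatter of two such steps. Each single step still lies within the scatter, so this agreement does not show that nitro truly outperforms cyano, and two cores in one assay do not make a rule for the whole series.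

The compounds shown leave open how an amine or a carboxylic acid on that aromatic carbon would compare with cyano and nitro. They also leave open whether the step would look the same on any further core.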